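This account rests on a few compounds, and the source may have more. Where it says the series, first, only, none or still open, it means among the compounds named here.

Measured compounds:
- compound 1 `CC(=O)N1CCc2c(c(-c3ccc(C(F)(F)F)cc3)nn2CC(O)CN2CCC(c3coc4cc(F)ccc34)CC2)C1`: in an assay on isolated protein for inhibition of cathepsin S (Homo sapiens) (a lower number here means a stronger inhibitor, a higher number a weaker inhibitor), compound 1 gives 360 nM
- compound 2 `CC(=O)N1CCc2c(c(-c3ccc(C(F)(F)F)cc3)nn2CC(O)CN2CCC(c3csc4cc(F)ccc34)CC2)C1`: in this assay compound 2 gives 290 nM

Compound 2 holds the lowest of the two numbers, with compound 1 nearest; the step of a 1.2-fold lower number from compound 1 to compound 2 (0.09 log units; within the scatter) lies within the scatter. Compound 3 `COC(=O)c1sc2cc(F)ccc2c1C1CCN(CC(O)Cn2nc(-c3ccc(C(F)(F)F)cc3)c3c2CCN(C(C)=O)C3)CC1` differs from compound 2 by methoxycarbonyl in place of hydrogen on an aromatic carbon. For the measured compounds named here, no measured step bears on this change: the only step, a 1.2-fold lower number from compound 1 to compound 2 (0.09 log units; within the scatter), exchanges one fused heteroaromatic group for another and is itself within the scatter. For compound 3 no step beyond the scatter is therefore expected in this assay, in either direction, with a wide range. Compound 3 is estimated at 300 nM (range 90 nM to 1000 nM). The expected step is a 1.0-fold higher number from compound 2 to compound 3 (0.01 log units; within the scatter).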

Compound 3, half-maximal inhibitory concentration: 140 nM
Compound 3: middle estimate off by 2.1-fold (0.33 log units), on the high side; the measured number falls inside the stated range.
By their numbers in this assay, from the lowest: compound 3; then compounds 2 and 1 (each within the scatter of the next).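

On the five-membered aromatic ring, the carbon next to the ring sulfur and next to the ring atom that bears a large group accepts methoxycarbonyl in this assay: the change gives a 2.1-fold lower number from compound 2 to compound 3 (0.32 log units; beyond the scatter) and is the only step shown beyond the scatter. Here, 4 heavy atoms in place of hydrogen cost no inhibition. No measured evidence accounts for this step. Going by these compounds, whether a carboxylic acid or a methyl group at this position would move the number in the same direction stays open. So does whether methoxycarbonyl would do the same on the 6-fluoro-1-benzofuran-3-yl group of compound 1.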